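Aryl groups on the ring amine nitrogen: compound 4

The source may report more compounds than this note shows. Statements on the series, on what has been measured and on what is new or still open speak of the compounds shown alone.

Among the compounds with values here, compound 1 `CC(C)N1CCN(Cc2csc(N)c2C(=O)c2ccc(Cl)cc2)CC1` stands at the bottom of the three numbers so far. In an assay on CHO cells for displacement of a labelled ligand from adenosine receptor A3 (Homo sapiens), read by scintillation counting, with a stated time of 120 min, tested at 10 uM (on this read-out lower numbers stand for less inhibition and higher numbers for more inhibition at the one concentration tested (going by the name of the read-out)), compound 1 gives 0%. Compound 2 `Nc1scc(CN2CCN(c3ccncc3)CC2)c1C(=O)c1ccc(Cl)cc1` gives 2% in this assay, and compound 3 `Nc1scc(CN2CCN(c3cccc4ccccc34)CC2)c1C(=O)c1ccc(Cl)cc1` gives 0%. The steps from compound 1 are a number 2 percentage points higher from compound 1 to compound 2 (within the scatter) and no change at the digits printed from compound 1 to compound 3 (within the scatter), so compound 1 is level with compound 3 and cannot be ordered against compound 2.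

Compound 4 `Nc1scc(CN2CCN(c3ccc(F)c(F)c3)CC2)c1C(=O)c1ccc(Cl)cc1` differs from compound 1 in one place: 3,4-difluorophenyl in place of isopropyl on an amine nitrogen in a ring. Within the data shown here, two measured steps bear on this change, both exchanging isopropyl for an aromatic group on the same amine nitrogen in a ring, and neither moved the read-out beyond the scatter, whether the entering group was pyridin-4-yl or naphthalen-1-yl. A third aromatic group, 3,4-difluorophenyl, is therefore expected to leave the number where it is, and the expected step is a number 1 percentage points higher from compound 1 to compound 4 (within the scatter), none beyond the scatter. The estimate for compound 4 in this assay is 1%, with a range from -5% to 10%.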

Compound 4, a percentage reported as inhibition, at one concentration (the size of the read-out at that concentration, not a potency): 1%
The estimate for compound 4 equals the measured number at the digits printed, within the range that was stated.
By their numbers in this assay, from the lowest: compounds 1, 3, 4 and 2 (each within the scatter of the next).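

In this assay, 3,4-difluorophenyl on the amine nitrogen in a ring reads the same as the other groups at this place, within the scatter, against isopropyl (a number 1 percentage points higher from compound 1 to compound 4 (within the scatter)), naphthalen-1-yl (a number 1 percentage points higher from compound 3 to compound 4 (within the scatter)) and pyridin-4-yl (a number 1 percentage points lower from compound 2 to compound 4 (within the scatter)). The flat result now extends to an aromatic ring of carbon only that carries fluorine, so neither that ring nor the fluorine shifts the number at this place in the four compounds shown. No measurement at hand bears on why the read-out stays flat.

Still open, going by these compounds, is whether any group on this nitrogen moves the number, such as a benzyl group, an acetyl group or a chain ending in a carboxylic acid. Also open, on these data alone, is whether a change elsewhere on the shared core, such as an amide in place of the free amine, would do so.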